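A phenyl-for-pyridinyl swap on an inactive scaffold

This account rests on a few compounds, and the source may have more. Where it says the series, first, only, none or still open, it means among the compounds named here.

Of the compounds shown here, three have been tested in a functional assay on MCF7 cells (Homo sapiens) for cytotoxicity, read by MTT assay, with a stated time of 4 days (a lower number here means a stronger inhibitor, a higher number a weaker inhibitor), and a fourth awaits testing. Compound 1 `Cc1c(O)ccc2c1[C@H](Cn1cc(-c3ccccc3)nn1)[C@@]13CC(=O)[C@@](C)(CC[C@@H]21)C3` and compound 2 `Cc1c(O)ccc2c1[C@H](Cn1cc(-c3ccccn3)nn1)[C@@]13CC(=O)[C@@](C)(CC[C@@H]21)C3` share one core, whereas compound 3 `C=C1C[C@]23C[C@@]1(O)CC[C@@H]2c1cccc(C)c1[C@@H]3Cn1cc(-c2ccccn2)nn1` is built on another; how the cores of compound 3 and compound 2 differ is not broken down here.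

In this assay compound 1 gives > 20000 nM, which is a limit of the assay rather than a number. Compound 2 likewise gives > 20000 nM, again a limit. Compound 3 gives > 20000 nM in this assay, also a limit.

Compound 2 and compound 1 differ in a single place: phenyl in place of pyridin-2-yl on an aromatic carbon. The resulting step that the two limits leave unreadable from compound 2 to compound 1 cannot be sized, because both of its ends rest on (the limit of > 20000 nM in this assay, at which 3 of the 3 values shown sit).

Compound 4 `C=C1C[C@]23C[C@@]1(O)CC[C@@H]2c1cccc(C)c1[C@@H]3Cn1cc(-c2ccccc2)nn1` stands to compound 3 exactly as compound 1 stands to compound 2, through the same change: phenyl in place of pyridin-2-yl on an aromatic carbon. Its place on the ring is identical in both pairs, so this is the same change, not merely the same kind.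

The expectation for compound 4 therefore rests on two things: compound 3 gives only the limit > 20000 nM, and the same change left compound 2 and compound 1 at the limit of > 20000 nM in this assay, at which 3 of the 3 values shown sit, without a readable difference. On that basis compound 4 is expected to give 30000 nM in this assay, most likely as another limit, with a range estimated from 12000 nM to 100000 nM. The step from compound 3 to compound 4 is expected to be a step that the limit leaves unreadable from compound 3 to compound 4, that is, essentially no readable change.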

Compound 4, half-maximal inhibitory concentration: > 20000 nM
Compound 4 was reported as a limit (the forecaster's own chance of this, stated with the estimate: 85%); the middle value does not contradict the limit.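

In this assay, no size can be given to the swap of pyridin-2-yl for phenyl between compound 3 and compound 4, because both compounds rest on a limit of the assay and not on a number: the limit of > 20000 nM in this assay, at which 4 of the 4 values shown sit.

The four compounds shown leave open whether this swap changes the cytotoxicity at all on either core, and what activity, if any, lies beyond the limit.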